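The compounds below may be only part of what the source reports. "The series", "measured", "known", "first", "only" and "open" are said of these compounds alone.

Measured so far in an assay on isolated protein for inhibition of Rho-associated protein kinase 2 (Homo sapiens), read by scintillation counting, radiometric assay and 33P incorporation, with a stated time of 40 min, in the presence of a further agent that is not named here; a higher number here means a weaker inhibitor, a lower number a stronger inhibitor: compound 2 `CN(C)c1ccc(C(=O)Nc2cc(F)cc(NC(=O)COc3ccc4c(=O)ccoc4c3)c2)cc1` gives 22 nM, and compound 3 `CN(C)c1ccc(C(=O)Nc2cc(Br)cc(NC(=O)COc3ccc4c(=O)ccoc4c3)c2)cc1` gives 4560 nM. Compound 1 `Cc1cc(NC(=O)COc2ccc3c(=O)ccoc3c2)cc(NC(=O)c2ccc(N(C)C)cc2)c1` reaches only the assay's limit, > 10000 nM.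

Of the two actual numbers, compound 3 holds the higher one, its nearest neighbour being compound 2 with a 210-fold higher number from compound 2 to compound 3 (2.32 log units; beyond the scatter) between them. Compound 1 sits at a limit, (the limit of > 10000 nM in this assay, at which 1 of the 3 values shown sits), so its distance from compound 3 is only bounded.

Compound 4 `CN(C)c1ccc(C(=O)Nc2cc(NC(=O)COc3ccc4c(=O)ccoc4c3)cc(C(F)(F)F)c2)cc1` differs from compound 3 by trifluoromethyl in place of bromo on an aromatic carbon. Within the data shown here, no measured step swaps bromo for trifluoromethyl. The steps on the same aromatic carbon are an at least 2.1-fold lower number from compound 1 to compound 3 (0.34 log units; beyond the scatter) and a 210-fold higher number from compound 2 to compound 3 (2.32 log units; beyond the scatter), showing fluoro far ahead of bromo, and bromo only a little ahead of methyl. Compound 4 is therefore expected to land near compound 3, with a 1.1-fold higher number from compound 3 to compound 4 (0.04 log units; within the scatter) as a rough guess. Compound 4 is estimated at 5000 nM, between 1000 nM and 20000 nM.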

Compound 4, half-maximal inhibitory concentration: > 10000 nM
Compound 4: a limit, no number (the forecaster's own chance of this, stated with the estimate: 30%); at least 2.0-fold (0.30 log units) between middle value and limit.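

Compound 4 gives only a limit of the assay, not a number: the limit of > 10000 nM in this assay, at which 2 of the 4 values shown sit. On this aromatic carbon, trifluoromethyl in place of bromo makes the inhibitor weaker, with an at least 2.1-fold higher number from compound 3 to compound 4 (0.34 log units; beyond the scatter), and the gain from fluoro is now seen against a third larger group, with an at least 450-fold higher number from compound 2 to compound 4 (2.65 log units; beyond the scatter). Among the four groups shown here, fluoro alone gives a low number, and the step between the two limits, compound 1 and compound 4, cannot be read.

On these data alone, what a chloro, a nitrile or an amine would give on this carbon stays open. So does how far compound 4 lies past its limit.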